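A few compounds are considered here, and "the series" means these few. Any claim that something is new, unique, unknown or untested is made for them only; others in the source may bear on it.

Working notes on a physicochemical assay for solubility, in phosphate buffer, measured as kinetic solubility, at pH 7.4 (a higher number here means a more soluble compound, a lower number a less soluble compound), for the series. Compound 1 `Cc1oc(-c2c(Br)cccc2Br)nc1CN1CCC(C(=O)NCCCN2C[C@H](C)C[C@H](C)C2)CC1` gives 62.4 ug/mL as a measured number. Compound 2 `Cc1oc(-c2c(Cl)cccc2Br)nc1CN1CCC(C(=O)NCCCN2C[C@H](C)C[C@H](C)C2)CC1` reads > 83 ug/mL as a limit. Compound 3 `Cc1cccc(F)c1-c1nc(CN2CCC(C(=O)NCCCN3C[C@H](C)C[C@H](C)C3)CC2)c(C)o1` reads > 72 ug/mL as a limit too, so it has no exact place on the numbers shown.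

Compound 4 `Cc1ccc(-c2nc(CN3CCC(C(=O)NCCCN4C[C@H](C)C[C@H](C)C4)CC3)c(C)o2)cc1` differs from compound 3 by one change on an aromatic carbon, next to the ring nitrogen and next to the ring oxygen: 4-methylphenyl in place of 2-fluoro-6-methylphenyl on an aromatic carbon (4-methylphenyl in place of 2-fluoro-6-methylphenyl).

Swaps on that carbon gave an at least 1.3-fold higher number from compound 1 to compound 2 (0.12 log units; that floor lies within the scatter) as one floor within the scatter, while the other comparison between limits is a step that the two limits leave unreadable from compound 2 to compound 3 and gives no size. For the measured compounds named here, no measured compound carries the 4-methylphenyl group, so the direction stays open. With an at least 1.1-fold higher number from compound 1 to compound 3 (0.06 log units; that floor lies within the scatter) as the nearest swap to go on, no step beyond the scatter is expected in this assay for compound 4.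

The estimated step is an at least 1.1-fold lower number from compound 3 to compound 4 (0.04 log units; that floor lies within the scatter) on this reading. For compound 4 the estimated value is 65 ug/mL (expected range 35 ug/mL to 85 ug/mL).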

Compound 4, solubility: > 69 ug/mL
Compound 4: only a limit was reported; the forecaster's own chance of this, stated with the estimate: 50%; at least 1.0-fold (0.02 log units) between middle value and limit.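

In this assay, compound 4 shows that a phenyl group without halogen, 4-methylphenyl, can sit on this aromatic carbon next to the ring nitrogen and next to the ring oxygen, and it too returns only a limit: the limit of > 69 ug/mL in this assay, at which 1 of the 4 values shown sits. For the compounds shown here, the one readable step is an at least 1.1-fold higher number from compound 1 to compound 4 (0.04 log units; that floor lies within the scatter), so the removal of both halogens from the series' phenyl group shows no change beyond the scatter. The steps among compound 2, compound 3 and compound 4 cannot be read, as each of these compounds has only a limit.

Going by these compounds, the actual values of compound 2, compound 3 and compound 4 remain open, and so does any ranking among the three. Also open, on these data alone, is what an amine or a carboxylic acid in place of the methyl of 4-methylphenyl would give at this carbon.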